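Swapping the aryl sulfonyl group on a quinoline scaffold

A few compounds are considered here, and "the series" means these few. Any claim that something is new, unique, unknown or untested is made for them only; others in the source may bear on it.

Of the compounds shown here, two have been measured in an assay on isolated protein for displacement of a labelled ligand from metabotropic glutamate receptor 5 (Homo sapiens), with a stated time of 60 min, tested at 1 uM; on this read-out lower numbers stand for less inhibition and higher numbers for more inhibition at the one concentration tested (going by the name of the read-out). Compound 1 `Cc1ccc(S(=O)(=O)c2cnc3ccc(Cl)cc3c2N2CCC(C)CC2)cc1F` gives 68%, and compound 2 `Cc1ccc2ncc(S(=O)(=O)c3ccc(C#N)cc3)c(N3CCC(C)CC3)c2c1` gives 55%, the lower of the two numbers and separated from compound 1 by a gap beyond the usual scatter. Compound 3 `Cc1ccc2ncc(S(=O)(=O)c3ccc(C)c(F)c3)c(N3CCC(C)CC3)c2c1` differs from compound 2 in one place: 3-fluoro-4-methylphenyl in place of 4-cyanophenyl on a sulfonyl sulfur. Among the measured compounds shown here, no such step has been measured yet. In this assay the step from compound 2 to compound 3 is expected to be a modest rise, a number 10 percentage points higher from compound 2 to compound 3 (within the scatter), because compound 1 carrying the same 3-fluoro-4-methylphenyl gives 68%. Compound 3 is therefore estimated at 65%, likely between 45% and 85%.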

Compound 3, a percentage reported as inhibition, at one concentration (the size of the read-out at that concentration, not a potency): 91%
Compound 3: middle estimate off by 26 percentage points, on the low side; measured number above the stated range.
By their numbers in this assay, from the lowest: compound 2; then compound 1; then compound 3.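

On a sulfonyl sulfur, 3-fluoro-4-methylphenyl in place of 4-cyanophenyl gives a number 36 percentage points higher from compound 2 to compound 3 (beyond the scatter), so the choice of aryl group here clearly affects the read-out while the rest of the molecule stays the same. On an aromatic carbon of the core, methyl in place of chloro gives a number 23 percentage points higher from compound 1 to compound 3 (beyond the scatter), so this second place matters as well. Nothing available explains either step. It remains open which part of 3-fluoro-4-methylphenyl accounts for the rise. A plain 4-methylphenyl or 3-fluorophenyl on the sulfonyl sulfur would separate the two.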